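Amide substituent notes: compound 2 to compound 3

The source may hold more compounds than are shown below. What is called first, only, known or untested is meant among the compounds shown, and "the series" means these compounds.

Compound 1 `CC1CCN(C(=O)c2c(N)sc(-c3ccc(Cl)cc3)c2-c2ccc(Cl)cc2)CC1` (1750 nM)
Compound 2 `Nc1sc(-c2ccc(Cl)cc2)c(-c2ccc(Cl)cc2)c1C(=O)NC1CCC(O)CC1` (250 nM)
Compound 3 `CCCCNC(=O)c1c(N)sc(-c2ccc(Cl)cc2)c1-c1ccc(Cl)cc1` (not yet measured)

Among the measured compounds shown here, in a functional assay on A549 cells (Homo sapiens) for inhibition, read by sulforhodamine B assay, with a stated time of 72 h (on this read-out higher numbers stand for weaker inhibition and lower numbers for stronger inhibition), compound 2 holds the lower of the two numbers so far (250 nM). The change to examine is butyl in place of 4-hydroxycyclohexyl on an amide-type nitrogen. For the measured compounds named here, one measured step bears on it: a 7.0-fold lower number from compound 1 to compound 2 (0.85 log units; beyond the scatter), which introduced the 4-hydroxycyclohexyl group. With that group leaving, a modest move to a higher number is expected in this assay, and the expected step is a 2.4-fold higher number from compound 2 to compound 3 (0.38 log units; beyond the scatter). The estimated value for compound 3 is 600 nM, within 200 nM to 2000 nM.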

Compound 3, half-maximal inhibitory concentration: 8170 nM
The estimate for compound 3 lay 14-fold (1.13 log units) below the measured number; measured number above the stated range.
By their numbers in this assay, from the lowest: compound 2; then compound 1; then compound 3.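

In this assay, replacing the ring with an open chain costs far more than the earlier step suggested: a 33-fold higher number from compound 2 to compound 3 (1.51 log units; beyond the scatter). Butylamino also falls behind 4-methylpiperidin-1-yl, a 4.7-fold higher number from compound 1 to compound 3 (0.67 log units; beyond the scatter), so keeping the amide hydrogen does not by itself give a low number at this position. No available measurement accounts for the size of these steps. The change removes the ring and the hydroxyl together, so their shares remain unseparated. A cyclohexyl amide and a 4-hydroxybutyl amide would pull the two apart.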